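The source may hold more compounds than are shown below. What is called first, only, known or untested is meant among the compounds shown, and "the series" means these compounds.

Compound 2 `c1ccc(-c2nc[nH]n2)c(NCC2=NCCN2)c1` gives the lowest number of the three measured in an in vitro functional assay on cells (Fibroblast) for agonist activity at Alpha-1A adrenergic receptor (Homo sapiens) (on this read-out lower numbers stand for an effect already at smaller amounts and higher numbers for an effect only at larger amounts of compound), at 0.794 nM; compound 1 `CCCn1ncnc1-c1ccccc1NCC1=NCCN1` gives 12.6 nM and compound 3 `CCCCn1ncnc1-c1ccccc1NCC1=NCCN1` gives 200 nM. The change to compound 4 `Cn1ccnc1-c1ccccc1NCC1=NCCN1` is 1-methyl-1H-imidazol-2-yl in place of 1H-1,2,4-triazol-3-yl on an aromatic carbon. Within the data shown here, no measured step matches it directly. Among the measured compounds shown here, the only single step known, a 16-fold higher number from compound 1 to compound 3 (1.20 log units; beyond the scatter), shows that lengthening the alkyl group on the ring nitrogen raises the number strongly, and compound 1, which carries a propyl on that nitrogen, sits well above compound 2. A methyl on the ring nitrogen is therefore expected to move the number up, but by less than the propyl-to-butyl step. Compound 4 is expected to give 5 nM (range 1 nM to 25 nM), a step of a 6.3-fold higher number from compound 2 to compound 4 (0.80 log units; beyond the scatter).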

Compound 4, half-maximal effective concentration: 6.31 nM
Compound 4: middle estimate off by 1.3-fold (0.10 log units), on the low side, and the stated range covers the measured number.
By their numbers in this assay, from the lowest: compound 2; then compounds 4 and 1 (each within the scatter of the next); then compound 3.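

In this assay, 1-methyl-1H-imidazol-2-yl in place of 1H-1,2,4-triazol-3-yl on this aromatic carbon gives a 7.9-fold higher number from compound 2 to compound 4 (0.90 log units; beyond the scatter) and so is a modest loss, not a large one. The change removes the hydrogen-bond donor, alters the ring hetero atoms and adds a methyl all at once, so the step cannot be divided among these differences. Nothing at hand accounts for the step. Still open, from the compounds shown here alone, is how the unmethylated 1H-imidazol-2-yl would read at this position, which would separate the methyl from the ring change.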